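The source may report more compounds than this note shows. Statements on the series, on what has been measured and on what is new or still open speak of the compounds shown alone.

Measured so far in an ADME assay (liver) for metabolic stability, with Liver microsome (Canis lupus familiaris) as the target, read by LC-MS, using microsomes, with a stated time of 30 min, tested at 4 uM; on this read-out higher numbers stand for a more stable compound and lower numbers for a less stable compound:
- compound 1 `Cc1nc(N2CCN(C)CC2)c2nc(-c3ccccc3Cl)n(CCO)c2n1`: 99%
- compound 2 `Cc1nc(N2CCN(C)CC2)c2nc(-c3ccccc3Cl)n(C3CC3)c2n1`: 98%
- compound 3 `Cc1nc(N2CCN(C)CC2)c2nc(-c3cccc(Cl)c3)n(C3CCOCC3)c2n1`: 45%

Compound 3 stands lowest of the three at 45%, and the numbers of compound 1 and compound 2 both lie beyond the scatter above it.

The next step leads to compound 4 `Cc1nc(N2CCN(C)CC2)c2nc(-c3cccc(C(F)(F)F)c3)n(C3CCOCC3)c2n1`, with trifluoromethyl in place of chloro on an aromatic carbon, meta to a large group: trifluoromethyl in place of chloro on an aromatic carbon.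

For the measured compounds named here, only one measured step links compounds that differ in one place: a number 1 percentage points lower from compound 1 to compound 2 (within the scatter). That change lies on an aromatic nitrogen, not on the aromatic carbon at issue here, so it gives only weak guidance. Going by the values given here, no measured step covers this replacement. In this assay, on these data alone, no step beyond the scatter is therefore expected, though either direction remains open and the range stays wide.

The expected step is a number 3 percentage points higher from compound 3 to compound 4 (within the scatter).

For compound 4, the estimated value is 48%, within an expected range of 28% to 70%.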

Compound 4, percent of the compound remaining: 44%
Beside the measured number, compound 4's estimate is 4 percentage points above it, within the range that was stated.
By their numbers in this assay, from the lowest: compounds 4 and 3 (each within the scatter of the next); then compounds 2 and 1 (each within the scatter of the next).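

In this assay, for the compounds shown here, the exchange of 3-chlorophenyl for 3-(trifluoromethyl)phenyl gives a number 1 percentage points lower from compound 3 to compound 4 (within the scatter) and is the first one-place change on an aromatic carbon, whereas the earlier step lay on an aromatic nitrogen. At this position, meta to a large group, the larger trifluoromethyl group and chloro therefore cannot be told apart on this read-out, and the pair stays well under the numbers of compound 1 and compound 2. No measurement at hand bears on why this exchange leaves the read-out within the scatter.

On these data alone, whether a nitrile, an amine or a carboxylic acid at this carbon would also stay within the scatter of chloro remains open. As far as these compounds go, compound 3 and compound 4 each differ from compound 1 and compound 2 in more than one place, so the separate contributions of the ring substituent's position and the group on the aromatic nitrogen also remain open.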